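A Shorter Tether Toward the Thioamide End

This account rests on a few compounds, and the source may have more. Where it says the series, first, only, none or still open, it means among the compounds named here.

The study reports a functional assay on the whole organism (stomach) with Rattus norvegicus as the target (on this read-out higher numbers stand for an effect only at larger amounts of compound and lower numbers for an effect already at smaller amounts), for three compounds built around the same core. Compound 1 `Cc1cc(=O)n(CCC(=N)S)nc1-c1ccccc1` is recorded in this assay only as a limit, > 100 mg/kg, which is the limit of > 100 mg/kg in this assay, at which 1 of the 3 values shown sits. Compound 2 `N=C(S)CCCCCCN1N=C(c2ccccc2)CCC1=O` gives 58.8 mg/kg in this assay, the higher of the two numbers reported. Compound 3 `C/N=C(/S)CCCCCn1nc(-c2ccccc2)ccc1=O` gives 25.2 mg/kg in this assay, a lower number than compound 2 by a gap beyond the usual scatter.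

Compound 4 `N=C(S)CCCCN1N=C(c2ccccc2)CCC1=O` is not yet measured. It differs from compound 2 by a group of 3 heavy atoms (1 carbon, 1 nitrogen, 1 sulfur; no ring) in place of a group of 5 heavy atoms (3 carbon, 1 nitrogen, 1 sulfur; no ring), on a saturated chain carbon, four bonds along the chain from an amide-type nitrogen in a ring, a group of 3 heavy atoms in place of a group of 5 heavy atoms on a saturated chain carbon, four bonds along the chain from an amide-type nitrogen in a ring. No measured pair differs in one place only, so the size of such a step is not shown by the data. The step from compound 2 to compound 4 is expected to be a 1.0-fold higher number from compound 2 to compound 4 (0.01 log units; within the scatter), small and within the scatter. Compound 4 is expected to give about 60 mg/kg in this assay, between 25 mg/kg and 150 mg/kg.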

Compound 4, dose for half-maximal effect: 100 mg/kg
For compound 4 the middle estimate is 1.7-fold (0.22 log units) below the measured one; the measured number falls inside the stated range.
By their numbers in this assay, from the lowest: compound 3; then compounds 2 and 4 (each within the scatter of the next).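

Among these compounds, the first measured pair that differs in one place gives a 1.7-fold higher number from compound 2 to compound 4 (0.23 log units; within the scatter) for a group of 3 heavy atoms in place of a group of 5 heavy atoms, on a saturated chain carbon, four bonds along the chain from an amide-type nitrogen in a ring. In this assay, among the compounds shown here, then, this change at this place is not separated from repeat measurement, and the earlier compounds could not show that. Compound 1 remains a limit and gives no number to set against this step: the limit of > 100 mg/kg in this assay, at which 1 of the 4 values shown sits.

For the compounds shown here, no single-place step yet links compound 3 to the others, so what its differences contribute one at a time stays open. Also open, from the compounds shown here alone, is how a longer chain, or an amine or a carboxylic acid in place of the thioamide end, would read in this assay.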